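The compounds below may be only part of what the source reports. "The series", "measured", "known", "first", "only" and "open" are said of these compounds alone.

Compound 1 `COc1cc(-c2cc(/C=C/C(=O)c3ccc(Cl)c(Cl)c3)[nH]n2)cc(OC)c1OC`: 89%
Compound 2 `COc1ccc(C(=O)/C=C/c2cc(-c3cc(OC)c(OC)c(OC)c3)n[nH]2)cc1OC`: 95%
Compound 3 `COc1ccc(C(=O)/C=C/c2cc(-c3cc(OC)c(OC)c(OC)c3)n[nH]2)cc1`: 97%

The three compounds were compared in a functional assay on BT-549 cells (Homo sapiens) for cytotoxicity, read by sulforhodamine B assay, with a stated time of 48 h, tested at 0.01 uM; on this read-out higher numbers stand for a weaker effect at the one concentration tested and lower numbers for a stronger effect. All three sit close together. Compound 3 has the highest number of the three, but its nearest neighbour, compound 2, lies within the scatter of it (a number 2 percentage points higher from compound 2 to compound 3 (within the scatter)), and so does compound 1 (a number 8 percentage points higher from compound 1 to compound 3 (within the scatter)). Compound 4 `COc1cc(-c2cc(/C=C/C(=O)c3ccc(F)c(F)c3)[nH]n2)cc(OC)c1OC` has not yet been measured. It differs from compound 3 at a single place: 3,4-difluorophenyl in place of 4-methoxyphenyl on a carbonyl carbon. The measured step that bears most on this change is the one in which a 3,4-dichlorophenyl on a carbonyl carbon gave way to a 4-methoxyphenyl, a shift within the scatter: a number 8 percentage points higher from compound 1 to compound 3 (within the scatter). The other swap of the same group, a number 6 percentage points higher from compound 1 to compound 2 (within the scatter), also stayed within the scatter. Placing 3,4-difluorophenyl where 4-methoxyphenyl stood is therefore expected to change little in this assay. The estimated step is a number 6 percentage points lower from compound 3 to compound 4 (within the scatter). Compound 4 is expected to give 91% in this assay, within a range of 82% to 100%.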

Compound 4, a percentage reported as activity, at one concentration (the size of the read-out at that concentration, not a potency): 101%
The estimate for compound 4 lay 10 percentage points below the measured number; measured number above the stated range.
By their numbers in this assay, from the lowest: compounds 1, 2, 3 and 4 (each within the scatter of the next, the first and the last beyond it).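

With the 3,4-difluorophenyl on the carbonyl carbon, replacing the 4-methoxyphenyl gives (a number 4 percentage points higher from compound 3 to compound 4 (within the scatter)) in this assay, and replacing the 3,4-dimethoxyphenyl gives (a number 6 percentage points higher from compound 2 to compound 4 (within the scatter)), so neither swap separates these compounds. Within the data shown here, the new finding is the first gap beyond the scatter at this position: replacing the 3,4-dichlorophenyl with the 3,4-difluorophenyl gives (a number 12 percentage points higher from compound 1 to compound 4 (beyond the scatter)), a modest step showing that the two halogen-bearing rings need not read alike here. Nothing available accounts for this gap.

From the compounds shown here alone, whether a ring bearing an amine or a carboxylic acid at this place would shift the number further remains open. A single concentration also leaves open how these compounds would compare across a range of doses.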